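The source may report more compounds than this note shows. Statements on the series, on what has been measured and on what is new or still open speak of the compounds shown alone.

Measured compounds in a functional assay on A549 cells (Homo sapiens) for cytotoxicity, read by MTT assay, with a stated time of 68 h; on this read-out higher numbers stand for weaker inhibition and lower numbers for stronger inhibition:

Compound 1, `COC(=O)c1ccc(-c2cccc(NC(=O)C(Cl)Cl)c2)cc1`: in this assay compound 1 gives only a limit, > 50000 nM.
Compound 2, `Nc1cccc(-c2cccc(NC(=O)C(Cl)Cl)c2)c1`: in this assay compound 2 gives 50000 nM.
Compound 3, `O=C(Nc1cccc(-c2cccc(Cl)c2)c1)C(Cl)Cl`: in this assay compound 3 gives 21400 nM.

Going by the values given here, compound 3 stands at the lowest of the two numbers in this assay; the nearest is compound 2, and the step of a 2.3-fold lower number from compound 2 to compound 3 (0.37 log units; beyond the scatter) is the only measured step in the set. Compound 1 sits at the limit of > 50000 nM in this assay, at which 1 of the 3 values shown sits, so its value is a limit and gives no number to place.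

Compound 4, `O=C(Nc1cccc(-c2ccccc2)c1)C(Cl)Cl`, follows from compound 3 by the change (hydrogen in place of chloro on an aromatic carbon). Among the compounds with values here, no measured pair shows this change. Within the data shown here, the one measured step, a 2.3-fold lower number from compound 2 to compound 3 (0.37 log units; beyond the scatter), concerns the same position and gave a modest lowering of the number when chloro replaced amino; the change from compound 3 to compound 4 takes the chloro away again without restoring the amino, so the two changes do not cancel and the step cannot simply be read in reverse. The expectation is that the number rises somewhat, or stays within the scatter of compound 3. The step of a 1.5-fold higher number from compound 3 to compound 4 (0.17 log units; within the scatter) is the expected outcome in this assay. For compound 4 the estimate in this assay is 32000 nM, within 13000 nM to 70000 nM.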

Compound 4, half-maximal inhibitory concentration: 8900 nM
Beside the measured number, compound 4's estimate is 3.6-fold (0.56 log units) above it; the measured number lies below the stated range.
By their numbers in this assay, from the lowest: compound 4; then compound 3; then compound 2.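

Hydrogen in place of chloro gives a 2.4-fold lower number from compound 3 to compound 4 (0.38 log units; beyond the scatter), so the lower number of compound 3 against compound 2 does not mark chloro as a group that lowers the number in this assay; it reflects only the comparison with amino. Hydrogen in place of amino gives a 5.6-fold lower number from compound 2 to compound 4 (0.75 log units; beyond the scatter), and hydrogen in place of methoxycarbonyl gives an at least 5.6-fold lower number from compound 1 to compound 4 (0.74 log units; beyond the scatter), so among these four compounds each substituent carries a higher number than the unsubstituted compound 4, with no compound going against this and chloro the smallest penalty of the measured steps. Compound 1 gives only a limit, so its step has no exact size: the limit of > 50000 nM in this assay, at which 1 of the 4 values shown sits.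

Still open, going by these compounds, is whether any group on this ring carbon can bring the number under that of compound 4; a fluoro, methyl, hydroxyl or methoxy group would test this. On these data alone, the amide group is the same in all four compounds, so the effect of replacing it with a monochloroacetamide or a plain acetamide also remains open.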